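Swapping a para bromo for methoxy on a cinnamoyl sulfonamide

The source may hold more compounds than are shown below. What is called first, only, known or untested is meant among the compounds shown, and "the series" means these compounds.

Measured compounds:
compound 1 `O=C(/C=C/c1ccccc1)NS(=O)(=O)c1ccccc1` gives 3.5 ug/mL in a functional assay on B16-F10 cells (Mus musculus) for antiproliferative activity, read by ELISA and MTT assay, with a stated time of 48 h; a higher number here means a weaker inhibitor, a lower number a stronger inhibitor
compound 2 `O=C(/C=C/c1ccc(Br)cc1)NS(=O)(=O)c1ccccc1` gives 3.9 ug/mL in this assay

On the two numbers shown, compound 2 has the highest reading, but its only neighbour, compound 1, sits so close that the two cannot be told apart; the difference a 1.1-fold higher number from compound 1 to compound 2 (0.05 log units; within the scatter) stays within the scatter of the method. Compound 3 `COc1ccc(/C=C/C(=O)NS(=O)(=O)c2ccccc2)cc1` has not yet been tested in this assay. Its structure differs from compound 2 in one place: methoxy in place of bromo on an aromatic carbon.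

Going by the values given here, only one measured step bears on this change, and it is indirect. The step of a 1.1-fold higher number from compound 1 to compound 2 (0.05 log units; within the scatter) shows that placing a substituent at this position of the ring left the number essentially unchanged. Nothing measured speaks to methoxy itself. The expected step of a 1.1-fold lower number from compound 2 to compound 3 (0.02 log units; within the scatter) is therefore small, with no clear direction. Compound 3 is estimated at 3.7 ug/mL, with a likely range from 1.8 ug/mL to 7.5 ug/mL.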

Compound 3, half-maximal inhibitory concentration: 13.2 ug/mL
Compound 3: the middle estimate sits 3.6-fold (0.55 log units) below what was measured; measured number above the stated range.
By their numbers in this assay, from the lowest: compounds 1 and 2 (each within the scatter of the next); then compound 3.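

This position is not indifferent to what sits on it: in this assay, methoxy gives a weaker inhibitor than bromo, with a 3.4-fold higher number from compound 2 to compound 3 (0.53 log units; beyond the scatter), and a weaker one than hydrogen, with a 3.8-fold higher number from compound 1 to compound 3 (0.58 log units; beyond the scatter). Both steps are modest but beyond the scatter, so the lack of a clear change between hydrogen and bromo does not extend to every group placed para to a large group. Nothing available here explains why methoxy behaves differently from bromo at this place.

As far as these compounds go, it remains open whether this weakening is specific to methoxy or also appears with a hydroxyl, an amine or a longer chain such as ethoxy. The compounds shown also leave open whether methoxy would have the same effect on another carbon of this ring.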